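A few compounds are considered here, and "the series" means these few. Any claim that something is new, unique, unknown or untested is made for them only; others in the source may bear on it.

Measured so far, in a physicochemical assay for solubility, at pH 7; on this read-out lower numbers stand for lower solubility and higher numbers for higher solubility:
Compound 1 `CNC(=O)c1cc(Oc2ccc3nc(Nc4ccccc4)ncc3c2)ccn1`; compound 1 gives < 1000 nM, a limit of the assay.
Compound 2 `CNC(=O)c1cc(Oc2ccc3nc(Nc4cccc(OC(F)(F)F)c4)ncc3c2)ccn1`; compound 2 gives < 1000 nM, a limit of the assay.
Compound 3 `CNC(=O)c1cc(Oc2ccc3nc(Nc4ccc(Br)cc4)ncc3c2)ccn1`; compound 3 gives < 1000 nM, a limit of the assay.

Compound 3 stands where all three measured compounds stand, at the limit of < 1000 nM in this assay, at which 3 of the 3 values shown sit, so no number and no order among them can be read. The steps a step that the two limits leave unreadable from compound 1 to compound 2, a step that the two limits leave unreadable from compound 1 to compound 3 and a step that the two limits leave unreadable from compound 2 to compound 3 each run from one limit to another and carry no size.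

Compound 4 is `CNC(=O)c1cc(Oc2ccc3nc(Nc4ccc(OC(F)(F)F)cc4)ncc3c2)ccn1`. It differs from compound 3 by trifluoromethoxy in place of bromo on an aromatic carbon. The measured steps that bear on it, a step that the two limits leave unreadable from compound 1 to compound 2 and a step that the two limits leave unreadable from compound 2 to compound 3, involve the same trifluoromethoxy group, yet neither is readable, so no direction or size can be taken from them. The step that the limit leaves unreadable from compound 3 to compound 4 is therefore expected to stay within the scatter, with compound 4 most likely again reported only as a limit. Compound 4 is estimated at 400 nM, in a range from 50 nM to 3000 nM.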

Compound 4, solubility: < 1000 nM
Compound 4: a limit, no number; the forecaster's own chance of this, stated with the estimate: 80%; the middle value lies beyond the limit too.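

In this assay, no step among compound 1, compound 2, compound 3 and compound 4 can be read, as all four values are limits of the assay: the limit of < 1000 nM in this assay, at which 4 of the 4 values shown sit.

The compounds shown leave open how these four rank and whether exchanging hydrogen, bromo or trifluoromethoxy changes the read-out at all.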